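This account rests on a few compounds, and the source may have more. Where it says the series, first, only, none or still open, it means among the compounds named here.

Of the compounds shown here, three of a shared core have been measured in a physicochemical assay for lipophilicity, using the shake flask method, at pH 7.4; a higher number here means a more lipophilic compound, a lower number a more polar compound. Compound 1 `CCCC(Oc1ccc(-n2cccn2)cc1)c1ccc(C(=O)NCCC(=O)O)cc1` gives 1.7. Compound 2 `CCCC(Oc1ccc(-n2cc(C(F)(F)F)cn2)cc1)c1ccc(C(=O)NCCC(=O)O)cc1` gives 2.4, and compound 3 `CCCC(Oc1ccc(-n2cc(C(F)(F)F)c(C)n2)cc1)c1ccc(C(=O)NCCC(=O)O)cc1` gives 2.8. Compound 3 stands highest of the three, with compound 2 nearest and compound 1 furthest. The steps leading to it were a number 0.70 log units higher from compound 1 to compound 2 (beyond the scatter) and a number 0.40 log units higher from compound 2 to compound 3 (beyond the scatter), which together make a number 1.10 log units higher from compound 1 to compound 3 (beyond the scatter).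

Compound 4 `CCCC(Oc1ccc(-n2cc(OC)cn2)cc1)c1ccc(C(=O)NCCC(=O)O)cc1` differs from compound 3 in one place: 4-methoxy-1H-pyrazol-1-yl in place of 3-methyl-4-(trifluoromethyl)-1H-pyrazol-1-yl on an aromatic carbon. The step from compound 1 to compound 3 bears most directly on this change, since compound 4, like compound 1, carries neither the methyl nor the trifluoromethyl on the five-membered ring. Going by the values given here, the whole of that step is expected to be given back, and nothing among the measured compounds shows what the methoxy adds on its own. Compound 4 is therefore expected to give 1.7, within a range from 1.3 to 2.1. This estimate means a step of a number 1.10 log units lower from compound 3 to compound 4 (beyond the scatter), expected to be large and downward.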

Compound 4, distribution coefficient: 1.4
Estimate against measurement, compound 4: 0.30 log units above; low and high end bracket the measured number.
By their numbers in this assay, from the lowest: compounds 4 and 1 (each within the scatter of the next); then compound 2; then compound 3.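

In this assay, methoxy in place of hydrogen on the five-membered ring gives a number 0.30 log units lower from compound 1 to compound 4 (within the scatter) and so cannot be told apart from the unsubstituted ring of compound 1. Methoxy in place of trifluoromethyl gives a number 1.00 log units lower from compound 2 to compound 4 (beyond the scatter) and the full exchange of 4-methoxy-1H-pyrazol-1-yl for 3-methyl-4-(trifluoromethyl)-1H-pyrazol-1-yl gives a number 1.40 log units lower from compound 3 to compound 4 (beyond the scatter) so the higher numbers at this position belong to the compounds with trifluoromethyl, and a substituent on the ring does not by itself bring them. Nothing shown explains why these groups differ in this way.

Left open is whether ethoxy, a hydroxyl, an amine or a nitrile in the same place would also stay within the scatter of compound 1. Also open, on these data alone, is whether a number 0.40 log units higher from compound 2 to compound 3 (beyond the scatter) would be repeated by a methyl added on a ring that carries methoxy, as the ring of compound 4 does.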